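The compounds below may be only part of what the source reports. "The series", "measured", "known", "first", "only" and "open" are said of these compounds alone.

Working notes on the sulfone series. Compound 2 `COc1ccc(S(=O)(=O)c2cnc3ccc(C)cc3c2N2CCC(C)CC2)cc1Cl` carries a 3-chloro-4-methoxyphenyl on the sulfonyl sulfur; in an assay on isolated protein for displacement of a labelled ligand from metabotropic glutamate receptor 5 (Homo sapiens), with a stated time of 60 min, tested at 1 uM (on this read-out lower numbers stand for less inhibition and higher numbers for more inhibition at the one concentration tested (going by the name of the read-out)), compound 2 gives 93%, the highest of the three numbers measured. Going by the values given here, its nearest neighbour is compound 1 `COc1ccc(S(=O)(=O)c2cnc3ccc(C)cc3c2N2CCC(C)CC2)cc1`, which in this assay gives 62%; the single measured step, chloro in place of hydrogen on an aromatic carbon, is a number 31 percentage points higher from compound 1 to compound 2 (beyond the scatter). Among the compounds with values here, compound 3 `CCOC(=O)C1CCN(c2c(S(=O)(=O)c3ccccc3)cnc3ccccc23)CC1`, which differs from the others in several places at once, gives 33% in this assay; no single step joins it to compound 2, so only its value is noted.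

Compound 4 `Cc1ccc2ncc(S(=O)(=O)c3ccc(F)cc3)c(N3CCC(C)CC3)c2c1` is the next compound for this assay. Relative to compound 2 the change is 4-fluorophenyl in place of 3-chloro-4-methoxyphenyl on a sulfonyl sulfur. The chloro that entered from compound 1 to compound 2 is gone again in compound 4, so the step of a number 31 percentage points higher from compound 1 to compound 2 (beyond the scatter) bears on it and argues for a fall of similar size back toward compound 1. Within the data shown here, the methoxy group also leaves and a fluorine enters; no measured pair covers that exchange, so its contribution is unknown. The expected step is therefore a number 38 percentage points lower from compound 2 to compound 4 (beyond the scatter), a decrease beyond the scatter, with wide uncertainty. For compound 4 the estimate in this assay is 55%, within 30% to 80%.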

Compound 4, a percentage reported as inhibition, at one concentration (the size of the read-out at that concentration, not a potency): 90%
Estimate against measurement, compound 4: 35 percentage points below; measured number outside the range, above it.
By their numbers in this assay, from the lowest: compound 3; then compound 1; then compounds 4 and 2 (each within the scatter of the next).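

In this assay the change at the sulfonyl sulfur to 4-fluorophenyl in place of 3-chloro-4-methoxyphenyl is a step of a number 3 percentage points lower from compound 2 to compound 4 (within the scatter) and leaves the number level, so the chloro is not required for a reading in this range. Fluoro in place of methoxy on an aromatic carbon gives a number 28 percentage points higher from compound 1 to compound 4 (beyond the scatter) in this series, which sets a second single change from compound 1 beside the chloro step of a number 31 percentage points higher from compound 1 to compound 2 (beyond the scatter) and shows that both reach the same range of numbers. No measurement on hand accounts for either rise or for the near equality of the two aryl groups.

The compounds shown leave open whether a nitrile, a trifluoromethyl or an amine in place of the fluoro on that aromatic carbon would hold the number in this range, and whether chloro and fluoro together on the aryl group would add to one another. From the compounds shown here alone, with readings at one concentration only, and compounds 2 and 4 within the scatter of each other, any order of potency between these two also remains open.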